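The source may report more compounds than this note shows. Statements on the series, on what has been measured and on what is new or still open speak of the compounds shown alone.

Working notes on the series in an ADME assay on CHO cells (Cricetulus griseus) for inhibition, read by MTT assay; on this read-out higher numbers stand for weaker inhibition and lower numbers for stronger inhibition.

Three compounds carry readings. For the measured compounds named here, compound 1 `CCN(CC)Cc1cc(Nc2nc3ccccc3n2Cc2ccc(C(F)(F)F)cc2)ccc1O` gives 17500 nM in this assay, the only plain number in the set. Compound 2 `CCN(CC)Cc1cccc(Nc2nc3ccccc3[nH]2)c1O` reaches only a limit of this assay, > 50000 nM. Compound 3 `CCN(CC)Cc1cccc(Nc2nc3ccccc3n2Cc2ccc(C(F)(F)F)cc2)c1O` likewise sits at a limit, > 50000 nM.

Going by the values given here, the one measured step is a step that the two limits leave unreadable from compound 3 to compound 2, the change being (hydrogen in place of 4-(trifluoromethyl)benzyl on an aromatic nitrogen). Its size cannot be read, since both ends rest on (the limit of > 50000 nM in this assay, at which 2 of the 3 values shown sit). Compound 1 and compound 3 share the same atoms joined differently; the difference between the two cores is not broken down here.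

Compound 4 `CCN(CC)Cc1cc(Nc2nc3ccccc3[nH]2)ccc1O` is not yet measured. It differs from compound 1 by hydrogen in place of 4-(trifluoromethyl)benzyl on an aromatic nitrogen, the same change made from compound 3 to compound 2, with the same surroundings at the place of change. Since that measured step gives no readable size, the step expected from compound 1 to compound 4, a 2.3-fold higher number from compound 1 to compound 4 (0.36 log units; beyond the scatter), rests only on the unreadable a step that the two limits leave unreadable from compound 3 to compound 2 and on (the limit of > 50000 nM in this assay, at which 2 of the 3 values shown sit), which leaves open that compound 4 too ends at a limit. For compound 4 the estimate is 40000 nM, with a range from 15000 nM to 100000 nM.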

Compound 4, half-maximal inhibitory concentration: > 50000 nM
Compound 4 was reported as a limit; the forecaster's own chance of this, stated with the estimate: 50%; at least 1.2-fold (0.09 log units) between middle value and limit.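

In this assay, hydrogen in place of 4-(trifluoromethyl)benzyl on the aromatic nitrogen gives an at least 2.8-fold higher number from compound 1 to compound 4 (0.45 log units; beyond the scatter), so on the core of compound 1 the change leads to weaker inhibition, by a size beyond the scatter. On these data alone, compound 4 reads > 50000 nM, which is a limit, so the real size of this step stays open. The same change on the core of compound 3 cannot be read, so the two cores are not shown to respond alike or differently, only that nothing here conflicts, and the comparison stops at this point: the limit of > 50000 nM in this assay, at which 3 of the 4 values shown sit.

On that aromatic nitrogen only hydrogen and 4-(trifluoromethyl)benzyl appear, which leaves open how a plain benzyl, a benzyl bearing a carboxylic acid or a longer alkyl chain would read. As far as these compounds go, it also stays open whether anything other than the diethylaminomethyl group, such as a morpholine or a primary amine, would change the reading on either core.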